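A few compounds are considered here, and "the series" means these few. Any claim that something is new, unique, unknown or untested is made for them only; others in the source may bear on it.

Compound 1 `CC/N=C(\S)NCCCCCCn1nc(-c2ccccc2)ccc1=O` has the lower number of the two measured compounds: in a functional assay on the whole organism with Rattus norvegicus as the target, at a dose of 100 mg/kg (a lower number here means less inhibition, a higher number more inhibition at the dose given (going by the name of the read-out)), compound 1 gives -5.6%, the lowest of the two numbers shown. Among the measured compounds shown here, its nearest neighbour is compound 2 `CC(C)(C)/N=C(\S)NCCCCn1nc(-c2ccccc2)ccc1=O`, which in this assay reaches 33.6%; the step of a number 39.2 percentage points higher from compound 1 to compound 2 (beyond the scatter) is the only measured step in this set and it lies beyond the scatter. Compound 3 `CC/N=C(/NC#N)NCCCCCCn1nc(-c2ccccc2)ccc1=O` differs from compound 1 in another place: a group of 7 heavy atoms (4 carbon, 3 nitrogen; no ring) in place of a group of 5 heavy atoms (3 carbon, 1 nitrogen, 1 sulfur; no ring), on an amine nitrogen. For the measured compounds named here, no measured step touches this amine nitrogen, so the measured step from compound 1 to compound 2 offers no direct guide; it shows only that this series can move far in this assay with changes to the thiourea end of the chain. With that as the sole bearing, compound 3 is expected to stay near compound 1, with a modest estimated shift a number 13.6 percentage points higher from compound 1 to compound 3 (beyond the scatter) that does not clearly exceed the scatter. The estimated value for compound 3 in this assay is 8%, within a range from -20% to 40%.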

Compound 3, a percentage reported as inhibition, in the whole organism at one dose (the size of the read-out at that dose, not a potency): 29.1%
Beside the measured number, compound 3's estimate is 21.1 percentage points below it, and the stated range covers the measured number.
By their numbers in this assay, from the lowest: compound 1; then compounds 3 and 2 (each within the scatter of the next).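

On the amine nitrogen, putting the nitrile-bearing group of compound 3 in place of the sulfur-bearing group of compound 1 gives a large change in this assay, with a number 34.7 percentage points higher from compound 1 to compound 3 (beyond the scatter). Compound 2 had differed from compound 1 on a saturated chain carbon, whereas here that chain stays as it is, so a change on the amine nitrogen alone is enough for a step of this size. No evidence at hand accounts for the step.

The compounds shown leave open whether the nitrile itself matters or the rest of the entering group does, which a urea carbonyl or a plain amine in the same place would help to settle. They also leave open whether the same exchange would give a similar step on the chain of compound 2.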